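The compounds below may be only part of what the source reports. "The series", "measured", "known", "first", "only" and "open" are said of these compounds alone.

Working notes on the series. In a functional assay on MCF7 cells (Homo sapiens) for cytotoxicity, read by MTT assay, with a stated time of 72 h (on this read-out higher numbers stand for weaker inhibition and lower numbers for stronger inhibition), compound 1 `O=C(N/N=C/c1cccc(Br)c1)Nc1cc2c(Nc3ccc(F)c(Cl)c3)ncnc2cc1O[C@H]1CCOC1` gives 12400 nM. Compound 2 `O=C(N/N=C/c1ccc(F)cc1Cl)Nc1cc2c(Nc3ccc(F)c(Cl)c3)ncnc2cc1O[C@H]1CCOC1` gives 32200 nM, and compound 3 `O=C(N/N=C/c1cc(Br)c(O)c(Br)c1)Nc1cc2c(Nc3ccc(F)c(Cl)c3)ncnc2cc1O[C@H]1CCOC1` gives 5910 nM. Among these three numbers compound 1 stands second highest: the change from compound 1 to compound 2 brings a 2.6-fold higher number from compound 1 to compound 2 (0.41 log units; beyond the scatter), while the change from compound 1 to compound 3 brings a 2.1-fold lower number from compound 1 to compound 3 (0.32 log units; beyond the scatter). Between the two outer compounds the change brings a 5.4-fold lower number from compound 2 to compound 3 (0.74 log units; beyond the scatter).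

Compound 4 `CCN(CC)c1ccc(/C=N/NC(=O)Nc2cc3c(Nc4ccc(F)c(Cl)c4)ncnc3cc2O[C@H]2CCOC2)c(O)c1` has not yet been measured in this assay. It differs from compound 1 in one place: 4-(diethylamino)-2-hydroxyphenyl in place of 3-bromophenyl on a carbon with a double bond to nitrogen. The three measured steps all vary the same group on the carbon with a double bond to nitrogen, and all are modest, so a change of similar magnitude is the most that the data support here. Among the compounds with values here, compound 3, the one measured example carrying a hydroxyphenyl at that position, gave the lowest number, 5910 nM. Within the data shown here, on that basis a modest step downward is expected for compound 4, though the diethylamino group has no measured counterpart, which widens the range. Compound 4 is therefore estimated at 8000 nM, with a range from 3000 nM to 25000 nM. That estimate corresponds to an expected step of a 1.6-fold lower number from compound 1 to compound 4 (0.19 log units; within the scatter).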

Compound 4, half-maximal inhibitory concentration: 15600 nM
Compound 4: the middle estimate sits 2.0-fold (0.29 log units) below what was measured; low and high end bracket the measured number.
By their numbers in this assay, from the lowest: compound 3; then compounds 1 and 4 (each within the scatter of the next); then compound 2.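

At this position, on a carbon with a double bond to nitrogen, 4-(diethylamino)-2-hydroxyphenyl brings more heavy atoms, a hydrogen-bond donor and hydrogen-bond acceptors in place of 3-bromophenyl, yet this assay shows only a 1.3-fold higher number from compound 1 to compound 4 (0.10 log units; within the scatter), so this exchange gives no readable difference. A hydroxyphenyl at this carbon does not by itself give the lowest number, since replacing 3,5-dibromo-4-hydroxyphenyl with 4-(diethylamino)-2-hydroxyphenyl gives a 2.6-fold higher number from compound 3 to compound 4 (0.42 log units; beyond the scatter), and compound 4 goes against any such link, while replacing 2-chloro-4-fluorophenyl with the same group gives a 2.1-fold lower number from compound 2 to compound 4 (0.31 log units; beyond the scatter). No supporting information is available to explain these differences.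

The compounds shown leave open how the hydroxyl and diethylamino groups each contribute, as neither appears here apart from the other on an otherwise matching ring. They also leave open whether a dimethylamino group, a morpholine ring or a carboxylic acid on the phenyl ring at this carbon would stay with compounds 1 and 4 or move towards the number of compound 3.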